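A few compounds are considered here, and "the series" means these few. Any claim that something is new, unique, unknown or untested is made for them only; others in the source may bear on it.

In a functional assay on SiHa cells (Homo sapiens) for inhibition, read by sulforhodamine B assay (a lower number here means a stronger inhibitor of growth, a higher number a weaker inhibitor of growth), compound 1 (`c1ccc(-c2ccc(-c3ccc(-c4nc5ccccc5[nH]4)cc3)cc2)cc1`) gives 100000 nM, compound 2 (`Oc1ccc(-c2ccc(-c3ccc(-c4nc5ccccc5[nH]4)cc3)cc2)cc1`) gives 33300 nM and compound 3 (`Clc1cccc(-c2ccc(-c3ccc(-c4nc5ccccc5[nH]4)cc3)cc2)c1`) gives 100000 nM. Compound 3 is thus level with compound 1, together the highest of the three numbers. The next step leads to compound 4 (`COc1ccc(-c2ccc(-c3ccc(-c4nc5ccccc5[nH]4)cc3)cc2)cc1OC`), with 3,4-dimethoxyphenyl in place of 3-chlorophenyl on an aromatic carbon, para to a large group: 3,4-dimethoxyphenyl in place of 3-chlorophenyl on an aromatic carbon. Going by the values given here, three measured steps bear on it. Hydroxy in place of hydrogen gave a 3.0-fold lower number from compound 1 to compound 2 (0.48 log units; beyond the scatter), chloro in place of hydrogen gave no change at the digits printed from compound 1 to compound 3 (within the scatter), and 3-chlorophenyl in place of 4-hydroxyphenyl gave a 3.0-fold higher number from compound 2 to compound 3 (0.48 log units; beyond the scatter). Among the compounds with values here, no compound carrying 3,4-dimethoxyphenyl has been measured, so only a modest step towards a lower number is expected. The estimated step is a 2.0-fold lower number from compound 3 to compound 4 (0.30 log units; within the scatter). Compound 4 is expected at 50000 nM, with an estimated range of 20000 nM to 100000 nM.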

Compound 4, concentration for 50% growth inhibition: 6200 nM
The estimate for compound 4 lay 8.1-fold (0.91 log units) above the measured number, outside the stated range (below it).
By their numbers in this assay, from the lowest: compound 4; then compound 2; then compounds 1 and 3 (each within the scatter of the next).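

At this aromatic carbon, para to a large group, the ring substituents shift the number much further than hydroxy or chloro did: in this assay, 3,4-dimethoxyphenyl in place of 3-chlorophenyl gives a 16-fold lower number from compound 3 to compound 4 (1.21 log units; beyond the scatter), and in place of phenyl gives a 16-fold lower number from compound 1 to compound 4 (1.21 log units; beyond the scatter). It also goes beyond the 4-hydroxyphenyl group, with a 5.4-fold lower number from compound 2 to compound 4 (0.73 log units; beyond the scatter). No measurement shown here accounts for this gain. Whether both methoxy groups are needed remains open, since a single methoxy group is absent from the compounds shown. Going by these compounds, the effect of an amine or a carboxylic acid on this ring is also open.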